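Bromo for methoxy on a fluorinated indole-piperazine core

A few compounds are considered here, and "the series" means these few. Any claim that something is new, unique, unknown or untested is made for them only; others in the source may bear on it.

Measured so far:
compound 1 `COc1ccc(C(=O)N2CCN(CC(=O)N3CCN(CCCc4c[nH]c5ccccc45)CC3)CC2)cc1` gives 156000 nM
compound 2 `O=C(CN1CCN(C(=O)c2ccc(Br)cc2)CC1)N1CCN(CCCc2c[nH]c3ccccc23)CC1` gives 71900 nM
compound 3 `COc1cccc(C(=O)N2CCN(CC(=O)N3CCN(CCCc4c[nH]c5ccc(F)cc45)CC3)CC2)c1` gives 87100 nM

All three compounds were tested in an ADME assay on HEK293 cells (Homo sapiens) for cytotoxicity, read by MTT assay, with a stated time of 72 h; a lower number here means a stronger inhibitor, a higher number a weaker inhibitor. Compound 1 and compound 2 share one core and differ in a single place, (bromo in place of methoxy on an aromatic carbon). That exchange gives a step of a 2.2-fold lower number from compound 1 to compound 2 (0.34 log units; beyond the scatter). Compound 3 carries a different core; how its core differs from that of compound 1 is not broken down here. Its value and that of compound 2 lie within the usual scatter of each other, so nothing is made of their order.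

Compound 4 `O=C(CN1CCN(C(=O)c2cccc(Br)c2)CC1)N1CCN(CCCc2c[nH]c3ccc(F)cc23)CC1` has not yet been measured in this assay. It differs from compound 3 by bromo in place of methoxy on an aromatic carbon. This is the same kind of change as that from compound 1 to compound 2, but not the same: in compound 1 the group sits para to a large group, in compound 3 it sits meta to a large group. Because of a 2.2-fold lower number from compound 1 to compound 2 (0.34 log units; beyond the scatter), a step in the same direction is expected from compound 3 to compound 4, estimated at a 1.9-fold lower number from compound 3 to compound 4 (0.29 log units; within the scatter). Going by the values given here, the expectation rests on a single measured pair, and on a core that is not the one on which that pair was measured, so the range is kept wide. For compound 4 in this assay the estimate is 45000 nM, expected to fall between 20000 nM and 110000 nM.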

Compound 4, half-maximal inhibitory concentration: 40600 nM
Beside the measured number, compound 4's estimate is 1.1-fold (0.04 log units) above it; the range from low to high includes it.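

In this assay, bromo in place of methoxy gives a 2.1-fold lower number from compound 3 to compound 4 (0.33 log units; beyond the scatter), and the size of this step agrees with the one found earlier on the other core: the same change on two cores in this assay, a 2.2-fold lower number (0.34 log units; beyond the scatter) from compound 1 to compound 2 and a 2.1-fold lower number (0.33 log units; beyond the scatter) from compound 3 to compound 4, 1.0-fold (0.00 log units) apart, within the scatter of two such steps

Within these two pairs, then, the change carries from the core of compound 1 to the core of compound 3 with both its direction and its size intact, even though the group in compound 3 sits meta to a large group and the two pairs differ in more than the core alone. This does not establish a rule for the series, as two pairs cannot show that the step would hold on further cores, and they offer no explanation for why it is the same size on both.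

The compounds shown leave open whether a chloro group, a nitrile or an amine in the same place on the ring would give a similar step, or whether the step is particular to bromo. Also open is how far the step depends on where the group sits, since each core is shown with the exchange at only one place on the ring.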